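The source may report more compounds than this note shows. Statements on the series, on what has been measured and on what is new or still open speak of the compounds shown alone.

Measured compounds:
compound 1 `COc1ccc(C2=NN(c3ccccc3)C(c3ccc(C)cc3)C2S(=O)(=O)CC2=NCCO2)cc1`: 70.5%
compound 2 `COc1ccc(-c2nn(-c3ccccc3)c(-c3ccc(C)cc3)c2S(=O)(=O)CC2=NCCS2)cc1`: "not active" (no number reported)
compound 3 `COc1ccc(C2=NN(c3ccccc3)C(c3ccc(C)cc3)C2S(=O)(=O)CC2=NCCS2)cc1`: 50.7%

All values come from a functional assay, read by Griess assay, with a stated time of 150 min, tested at 100 ug/mL; a lower number here means a weaker effect, a higher number a stronger effect of the compound at the concentration tested. Compound 1 and compound 3 share one core and differ only in the ring on the sulfonyl side chain, (a group of 5 heavy atoms (3 carbon, 1 nitrogen, 1 oxygen; one five-membered non-aromatic ring with 2 hetero atoms) in place of a group of 5 heavy atoms (3 carbon, 1 nitrogen, 1 sulfur; one five-membered non-aromatic ring with 2 hetero atoms), on a saturated chain carbon bound to a sulfonyl sulfur); this change gives a number 19.8 percentage points higher from compound 3 to compound 1 (beyond the scatter). Compound 2 carries a different core; the difference between the two cores is not broken down here. In this assay compound 2 is reported as "not active" (no number reported) without a number, so no single value stands for it.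

Compound 4 `COc1ccc(-c2nn(-c3ccccc3)c(-c3ccc(C)cc3)c2S(=O)(=O)CC2=NCCO2)cc1` is not yet measured. It arises from compound 2 by the same kind of change as from compound 3 to compound 1, (a group of 5 heavy atoms (3 carbon, 1 nitrogen, 1 oxygen; one five-membered non-aromatic ring with 2 hetero atoms) in place of a group of 5 heavy atoms (3 carbon, 1 nitrogen, 1 sulfur; one five-membered non-aromatic ring with 2 hetero atoms), on a saturated chain carbon bound to a sulfonyl sulfur), with the same place line in both cases. That earlier step was modest and beyond the scatter. Applied to compound 2, which has no number, the step cannot be added to a starting value; the core of compound 2 and compound 4 gave no activity in the one compound measured, so only a weak effect is expected. Compound 4 is estimated at 20% in this assay, expected between 0% and 45%, with a real chance that it is again reported only as not active.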

Compound 4, a percentage reported as activity, at one concentration (the size of the read-out at that concentration, not a potency): 68.2%
For compound 4 the middle estimate is 48.2 percentage points below the measured one, outside the stated range (above it).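

Within the data shown here, compound 2 has no number in this assay, and no step from it to compound 4 can be read. The compounds shown leave open how large the change of ring on the sulfonyl side chain is on the core of compound 2 and compound 4 in this assay. No measured information bears on the reason for the result.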